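The source may report more compounds than this note shows. Statements on the series, on what has been measured and on what is new or still open speak of the compounds shown alone.

Three compounds have been measured in a functional assay on SF-268 cells (Homo sapiens) for inhibition, read by sulforhodamine B assay, with a stated time of 48 h; a lower number here means a stronger inhibitor of growth, a higher number a weaker inhibitor of growth:

compound 1 `N#CCC1=NN=C(c2ccc(Br)cc2)C(CC(=O)c2ccc(Br)cc2)O1`: 16900 nM
compound 2 `N#CCC1=NN=C(c2ccc(Br)cc2)C(CC(=O)c2ccc([N+](=O)[O-])cc2)O1`: 18500 nM
compound 3 `N#CCC1=C(C#N)CC(c2ccc(Br)cc2)=C(CC(=O)c2ccc(Br)cc2)O1`: 8200 nM

Compound 3 has the lowest number of the three, and its gaps to compound 1 and compound 2 both lie just beyond the usual scatter. Compound 4 `N#CCC1=C(C#N)CC(c2ccc([N+](=O)[O-])cc2)=C(CC(=O)c2ccc(Br)cc2)O1` has not yet been measured. It differs from compound 3 by nitro in place of bromo on an aromatic carbon.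

Within the data shown here, one measured step bears on this change. The same exchange gave a 1.1-fold higher number from compound 1 to compound 2 (0.04 log units; within the scatter), which is within the scatter. That exchange was made on a different aromatic ring of a different core, so it is only a loose guide. On this evidence, no step beyond the scatter is expected in this assay, in either direction. The expected change is a 1.1-fold higher number from compound 3 to compound 4 (0.04 log units; within the scatter). For compound 4 the estimated value is 9000 nM, with an expected range of 4500 nM to 18000 nM.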

Compound 4, concentration for 50% growth inhibition: 2800 nM
Beside the measured number, compound 4's estimate is 3.2-fold (0.51 log units) above it; the whole stated range lies above it.
By their numbers in this assay, from the lowest: compound 4; then compound 3; then compounds 1 and 2 (each within the scatter of the next).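

In this assay, 4-nitrophenyl in place of 4-bromophenyl gives a 2.9-fold lower number from compound 3 to compound 4 (0.47 log units; beyond the scatter), so this exchange can move the number by more than the scatter, which the earlier pair did not show. The exchange therefore does not carry one size from one setting to another; in the earlier pair it was made on a different aromatic ring of a different core, so the effects of ring and core cannot be told apart. The two steps compare as follows: the same change on two cores in this assay, a 1.1-fold higher number (0.04 log units; within the scatter) from compound 1 to compound 2 and a 2.9-fold lower number (0.47 log units; beyond the scatter) from compound 3 to compound 4, 3.2-fold (0.51 log units) apart, beyond the scatter of two such steps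

The compounds shown hold only bromo and nitro at this place, so it remains open whether an amine, a methoxy group or a carboxylic acid there would give a number nearer that of compound 3 or compound 4. Also open, from the compounds shown here alone, is how nitro on both aromatic rings of this core would read.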